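The source may report more compounds than this note shows. Statements on the series, on what has been measured and on what is new or still open speak of the compounds shown alone.

Measured so far in a functional assay on EC9706 cells (Homo sapiens) for cytotoxicity, read by MTT assay, with a stated time of 72 h; a lower number here means a stronger inhibitor, a higher number a weaker inhibitor:
- compound 1, `O=C(CSC(=S)N[C@H]1CCOC1=O)Nc1ccc(Br)cc1`: 67400 nM
- compound 2, `Cc1cccc(NC(=O)CSC(=S)N[C@H]2CCOC2=O)c1`: > 128000 nM

For the measured compounds named here, compound 1 is the only compound here with an actual number in this assay. For compound 2 the value is a limit of the assay, not a number. Going by the values given here, the one measured step, an at least 1.8-fold higher number from compound 1 to compound 2 (0.27 log units; that floor lies within the scatter), rests on that limit, (the limit of > 128000 nM in this assay, at which 1 of the 2 values shown sits).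

Compound 3, `CC(=O)c1ccc(NC(=O)CSC(=S)N[C@H]2CCOC2=O)cc1`, differs from compound 1 by acetyl in place of bromo on an aromatic carbon. Among the compounds with values here, no measured step covers an acetyl group, so the direction is open. Compound 3 is expected near 90000 nM, within 30000 nM to 250000 nM. That expectation amounts to a 1.3-fold higher number from compound 1 to compound 3 (0.13 log units; within the scatter).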

Compound 3, half-maximal inhibitory concentration: > 128000 nM
Compound 3: no number, only a limit (the forecaster's own chance of this, stated with the estimate: 40%); middle value at least 1.4-fold (0.15 log units) away from the limit.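

For compound 3, the result in this assay is a limit and not a number. Acetyl on the aromatic carbon that holds bromo in compound 1 gives an at least 1.8-fold higher number from compound 1 to compound 3 (0.27 log units; that floor lies within the scatter), a floor that leaves the true size of the change unknown. This is the first change at this aromatic carbon with the other ring substituents held the same, and it ends at the same limit as compound 2: the limit of > 128000 nM in this assay, at which 2 of the 3 values shown sit.

Going by these compounds, whether a chloro group, an amine or a carboxylic acid at this carbon would give a measurable number stays open. No order between compound 2 and compound 3 can be read.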